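Working notes: furan-3-yl in place of pyridin-2-yl

This account rests on a few compounds, and the source may have more. Where it says the series, first, only, none or still open, it means among the compounds named here.

In a functional assay on A549 cells (Homo sapiens) for cytotoxicity, read by MTT assay, with a stated time of 68 h (a lower number here means a stronger inhibitor, a higher number a weaker inhibitor), compound 1 `O=C(Nc1cccc(-c2ccccn2)c1)C(Cl)Cl` gives > 50000 nM, which is a limit of the assay and not a number. For the measured compounds named here, compound 2 `CSc1cccc(-c2cc(NC(=O)C(Cl)Cl)cc(-c3cccc(SC)c3)c2)c1` is the only compound so far with a numerical result, at 15900 nM. Compound 3 `O=C(Nc1cccc(-c2ccoc2)c1)C(Cl)Cl` carries furan-3-yl in place of pyridin-2-yl on an aromatic carbon, meta to a ((dichloromethyl)carbonyl)amino group: furan-3-yl in place of pyridin-2-yl on an aromatic carbon. Going by the values given here, no measured step bears on this exchange in this assay. A modest move towards stronger inhibition is expected, an estimated at least 1.4-fold lower number from compound 1 to compound 3 (0.15 log units; that floor lies within the scatter), and another limit would not be surprising. For compound 3 the expected value is 35000 nM, with an estimated range of 15000 nM to 70000 nM.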

Compound 3, half-maximal inhibitory concentration: 8480 nM
The estimate for compound 3 lay 4.1-fold (0.62 log units) above the measured number; the whole stated range lies above it.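

In this assay, the place meta to a ((dichloromethyl)carbonyl)amino group proves sensitive to the ring it carries: furan-3-yl in place of pyridin-2-yl gives an at least 5.8-fold lower number from compound 1 to compound 3 (0.77 log units; beyond the scatter). For the compounds shown here, this is the first readable step, and it lies beyond the scatter. Its full size cannot be read, because the result for compound 1 is a limit and not a number: the limit of > 50000 nM in this assay, at which 1 of the 3 values shown sits.

From the compounds shown here alone, it remains open whether thiophen-3-yl or phenyl at this place would match furan-3-yl. Also open, going by these compounds, is how a ring bearing an amine would compare.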